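The source may report more compounds than this note shows. Statements on the series, on what has been measured and on what is new or still open speak of the compounds shown alone.

Compound 2, `Nc1n[nH]c2cc(-c3ccc(=O)n(Cc4cccc(Cl)c4)c3)ccc12`, and compound 1, `Nc1n[nH]c2cc(-c3ccc(=O)n(Cc4ccccc4F)c3)ccc12`, share one core and differ only in the ring attached to the saturated chain carbon bound to an aromatic nitrogen. In an assay for inhibition of MAP kinase-interacting serine/threonine-protein kinase 2 (Homo sapiens), read by luminescence and ADP-Glo, with a stated time of 2 h (a lower number here means a stronger inhibitor, a higher number a weaker inhibitor), compound 1 gives 4 nM, and compound 2 gives 6 nM. Going by the values given here, compound 2 thus carries the higher of the two numbers measured so far, but the step of a 1.5-fold higher number from compound 1 to compound 2 (0.18 log units; within the scatter) lies within the scatter, so the two compounds cannot be separated on these data. Compound 3, `Nc1n[nH]c2cc(-c3ccc(=O)n(Cc4cccc(F)c4)c3)ccc12`, is compound 2 with fluoro in place of chloro on an aromatic carbon. Among the compounds with values here, the only measured step that bears on this change, a 1.5-fold higher number from compound 1 to compound 2 (0.18 log units; within the scatter), exchanged one halogenated ring for another and stayed within the scatter, so no step beyond the scatter is expected here either. Compound 3 is therefore expected to give about 5 nM in this assay, most likely between 2 nM and 12 nM, an expected step of a 1.2-fold lower number from compound 2 to compound 3 (0.08 log units; within the scatter).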

Compound 3, half-maximal inhibitory concentration: 5 nM
For compound 3 middle estimate and measured number coincide at the digits printed; the measured number falls inside the stated range.
By their numbers in this assay, from the lowest: compounds 1, 3 and 2 (each within the scatter of the next).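

Exchanging chloro for fluoro on the same aromatic carbon gives a 1.2-fold lower number from compound 2 to compound 3 (0.08 log units; within the scatter) in this assay, so this position does not separate the two halogens on these data. Keeping fluoro but using 3-fluorophenyl in place of 2-fluorophenyl gives a 1.3-fold higher number from compound 1 to compound 3 (0.10 log units; within the scatter), so these two placements of fluoro cannot be separated either. No measurement at hand accounts for these small steps.

The compounds shown carry only halogens on this ring, so it stays open whether an amine, a methoxy group or a carboxylic acid on that aromatic carbon would produce a step beyond the scatter. Also open, on these data alone, is what a longer chain between the ring and the aromatic nitrogen would do to the number.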